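Replacing the side chain of compound 1

This account rests on a few compounds, and the source may have more. Where it says the series, first, only, none or still open, it means among the compounds named here.

Compound 1 (`COc1cc(C2CN(C(=O)c3cc(OCCCC(=O)O)ccn3)C2)ccc1OCc1ccc(C2CC2)cc1`) gives 88% in an ADME assay on S9 fraction from liver (Mus musculus, strain CD-1) for metabolic stability, read by LC-MS, using NADPH, with stated times of 5 min and 60 min, tested at 5 uM; a higher number here means that more of the compound is left, a lower number that less of the compound is left. Among the compounds with values here, that is the higher of the two numbers measured so far, since compound 2 (`CCc1ccc(COc2ccc(C3CN(C(=O)c4cc(COC[C@@H](O)CO)ccn4)C3)cc2OC)cc1`) gives 26%, a gap well beyond the usual scatter. These two compounds differ in more than one place, so their gap cannot be tied to any single change.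

Compound 3 (`COc1cc(C2CN(C(=O)c3cc(COCC(CO)CO)ccn3)C2)ccc1OCc1ccc(C2CC2)cc1`) keeps the core of compound 1 and alters one chain, with (3-hydroxy-2-(hydroxymethyl)propoxy)methyl in place of 3-carboxypropoxy on an aromatic carbon, opposite the ring nitrogen ((3-hydroxy-2-(hydroxymethyl)propoxy)methyl in place of 3-carboxypropoxy on an aromatic carbon). Within the data shown here, no measured pair isolates this swap, so the forecast in this assay is uncertain. The best guide is compound 2, whose chain also bears hydroxyl groups and which gives 26%. A fall beyond the scatter is therefore expected, with an estimated step of a number 46 percentage points lower from compound 1 to compound 3 (beyond the scatter). For compound 3 the expected value is 42%, within an estimated range of 18% to 70%.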

Compound 3, percent of the compound remaining: 66%
For compound 3 the middle estimate is 24 percentage points below the measured one; measured number inside the range.
By their numbers in this assay, from the lowest: compound 2; then compound 3; then compound 1.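

Within the data shown here, the step of a number 22 percentage points lower from compound 1 to compound 3 (beyond the scatter) is the first reading of a single change in this assay, and it ties a real loss to one place: the aromatic carbon opposite the ring nitrogen, with the core of compound 1 left untouched. So what sits at this place does affect how much compound is left, although the step is modest, and (3-hydroxy-2-(hydroxymethyl)propoxy)methyl in place of 3-carboxypropoxy is one swap whose size is now known rather than guessed. No supporting measurement accompanies this result, so the step stands as an observation with no explanation attached.

The swap alters several features at once: the carboxylic acid leaves, hydroxyl groups enter, and the chain changes in length and in the atom that joins it to the ring, so the compounds shown leave open which of these features accounts for the step. Also open, as far as these compounds go, is how a chain ending in an amine, or a shorter chain carrying a single hydroxyl, would read at this same place on the core of compound 1.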